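A few compounds are considered here, and "the series" means these few. Any claim that something is new, unique, unknown or untested is made for them only; others in the source may bear on it.

Compound 1 `c1ccc(CSc2nnc(-c3ccc4c(c3)OCCO4)n2-c2ccccc2)cc1`: 7930 nM
Compound 2 `O=[N+]([O-])c1cccc(CSc2nnc(-c3ccc4c(c3)OCCO4)n2-c2ccccc2)c1`: 7590 nM
Compound 3 `COc1cccc(CSc2nnc(-c3ccc4c(c3)OCCO4)n2-c2ccccc2)c1`: 10100 nM

In a functional assay on SW 1116 cells (Homo sapiens) for antiproliferative activity, read by MTT assay, with a stated time of 24 h (on this read-out higher numbers stand for weaker inhibition and lower numbers for stronger inhibition), compound 3 gives 10100 nM, a number within the usual scatter of the values for the other two compounds. Compound 4 `Cc1ccccc1CSc1nnc(-c2ccc3c(c2)OCCO3)n1-c1ccccc1` has not yet been measured. It differs from compound 3 as follows: 2-methylphenyl in place of 3-methoxyphenyl on a saturated chain carbon bound to a sulfur. The measured steps that bear on this change are a 1.0-fold lower number from compound 1 to compound 2 (0.02 log units; within the scatter), a 1.3-fold higher number from compound 1 to compound 3 (0.11 log units; within the scatter) and a 1.3-fold higher number from compound 2 to compound 3 (0.12 log units; within the scatter). All three swap groups on the same aromatic ring and stay within the scatter, though none of them introduces a methyl group. No clear shift in either direction is therefore expected. The expected change is a 1.3-fold lower number from compound 3 to compound 4 (0.10 log units; within the scatter). For compound 4 the estimate is 8000 nM, with an expected range of 3500 nM to 16000 nM.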

Compound 4, half-maximal inhibitory concentration: 12700 nM
The estimate for compound 4 lay 1.6-fold (0.20 log units) below the measured number, and the stated range covers the measured number.
By their numbers in this assay, from the lowest: compounds 2, 1, 3 and 4 (each within the scatter of the next).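

In this assay, 2-methylphenyl on the saturated chain carbon bound to a sulfur stays within the scatter of all three earlier compounds (a 1.6-fold higher number from compound 1 to compound 4 (0.20 log units; within the scatter)) (a 1.7-fold higher number from compound 2 to compound 4 (0.22 log units; within the scatter)) (a 1.3-fold higher number from compound 3 to compound 4 (0.10 log units; within the scatter)). A methyl group, placed as in 2-methylphenyl, therefore joins the nitro and methoxy groups of 3-nitrophenyl and 3-methoxyphenyl as a swap with no readable effect on this ring. Nothing available explains this flat result. Still open, from the compounds shown here alone, is whether any group here can move the number beyond the scatter. An amine or a carboxylic acid on this ring, or a longer chain in place of the benzyl group, would test that.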